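This account rests on a few compounds, and the source may have more. Where it says the series, first, only, none or still open, it means among the compounds named here.

In a functional assay on KBVIN cells (Homo sapiens) for antiproliferative activity, read by sulforhodamine B assay, with a stated time of 3 days (on this read-out higher numbers stand for an effect only at larger amounts of compound and lower numbers for an effect already at smaller amounts), compound 2, whose structure is `CCC1=C(O)c2c(oc(-c3ccc(O)cc3)cc2=O)C(CC)(CC)C1=O`, gives 20.6 uM. Among the measured compounds shown here, only one other compound has been measured: compound 1, with structure `CCC1=C(O)c2c(oc(-c3ccc(CC(C)C)cc3)cc2=O)C(CC)(CC)C1=O`, gives 17.4 uM in this assay. Compound 2 and compound 1 therefore sit within the usual scatter of each other, so the two numbers cannot be told apart.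

The next compound, compound 3, has structure `CCC1=C(O)c2c(oc(-c3ccccc3C)cc2=O)C(CC)(CC)C1=O`. Compared with compound 2 the change is 2-methylphenyl in place of 4-hydroxyphenyl on an aromatic carbon. For the measured compounds named here, the only measured step, a 1.2-fold higher number from compound 1 to compound 2 (0.07 log units; within the scatter), swapped one group for another at the same aromatic carbon and moved the number by less than the scatter. Going by the values given here, that step bears on the present one, since the new change again exchanges the group attached at this carbon, but no measured pair shows a 2-methylphenyl. The expected step of a 1.1-fold lower number from compound 2 to compound 3 (0.06 log units; within the scatter) is therefore small, with no direction beyond the scatter. Compound 3 is estimated at 18 uM, within a range from 8 uM to 40 uM.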

Compound 3, concentration for half-maximal effect: 2.41 uM
Compound 3: the middle estimate sits 7.5-fold (0.87 log units) above what was measured; measured number outside the range, below it.
By their numbers in this assay, from the lowest: compound 3; then compounds 1 and 2 (each within the scatter of the next).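

In this assay, among the compounds shown here, this aromatic carbon proves sensitive to what it carries: an 8.5-fold lower number from compound 2 to compound 3 (0.93 log units; beyond the scatter), whereas the earlier exchange at the same carbon, a 1.2-fold higher number from compound 1 to compound 2 (0.07 log units; within the scatter), gave no step that could be told from noise. Going from 4-hydroxyphenyl to 2-methylphenyl changes two things at once, the substituent on the phenyl ring and its numbered place on that ring, and the entering group also has no hydrogen-bond donor or acceptor. Nothing available explains why the number falls.

The compounds shown leave open whether the methyl group or its place on the ring carries the step. A 4-methylphenyl or a 2-hydroxyphenyl group would separate the two, and a 2-aminophenyl group would show whether another substituent at that place behaves alike.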